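The compounds below may be only part of what the source reports. "The series", "measured", "known", "first", "only" and "open" are said of these compounds alone.

Measured so far:
compound 1 `COC(=O)C1=CO[C@@H](O[C@@H]2O[C@H](CO)[C@@H](O)[C@H](O)[C@H]2O)[C@@H]2[C@@H](COC(=O)/C=C\c3ccc(O)cc3)CC[C@H]12` — 100000 nM
compound 2 `CC(C)CC(=O)O[C@@H]1OC=C(CO[C@@H]2O[C@H](CO)[C@@H](O)[C@H](O)[C@H]2O)[C@H]2C[C@H](OC(=O)/C=C\c3ccc(O)cc3)[C@](O)(CO)[C@@H]12` — 4670 nM

In a functional assay on HeLa S3 cells (Homo sapiens) for cytotoxicity, read by WST assay (a lower number here means a stronger inhibitor, a higher number a weaker inhibitor), compound 1 gives 100000 nM, the highest of the two numbers in hand. Compound 2 gives 4670 nM in this assay. Among the measured compounds shown here, no one-place step between compound 1 and compound 2 is counted; the two numbers simply show a wide gap, and nothing more is drawn from that pair.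

Compound 3 `COC(=O)C1=CO[C@@H](O[C@@H]2O[C@H](CO)[C@@H](O)[C@H](O)[C@H]2O)[C@@H]2[C@@H](COC(=O)/C=C/c3ccc(O)cc3)CC[C@H]12` is the next entry. Compared with compound 1, (the two compounds have the same atoms and bonds and differ only in configuration as drawn: 1 of 10 stereo elements differ; a double bond is drawn Z in compound 1 and E in compound 3). For the measured compounds named here, no step of this kind has been measured, so nothing in hand fixes its size or direction; the working expectation is a step of a 1.1-fold lower number from compound 1 to compound 3 (0.05 log units; within the scatter) that stays within the scatter of this assay. On that basis compound 3 is expected to give about 90000 nM in this assay, with a plausible range from 30000 nM to 200000 nM.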

Compound 3, half-maximal inhibitory concentration: 100000 nM
The estimate for compound 3 lay 1.1-fold (0.05 log units) below the measured number, within the range that was stated.
By their numbers in this assay, from the lowest: compound 2; then compounds 1 and 3 (each within the scatter of the next).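

In this assay, the geometry of the double bond is now tested directly, which the earlier pair could not do, and the result is no change at the digits printed from compound 1 to compound 3 (within the scatter). Among the compounds shown here, this is the first one-place comparison, and it isolates a single stereo element: the fact that compounds 1 and 3 differ only in the configuration as drawn. On this shared core, therefore, drawing the double bond Z or E does not separate the two compounds in this assay, though this single pair says nothing about other cores.

As far as these compounds go, it remains open whether the same change would read alike on compound 2 (4670 nM), which also carries the Z double bond. Also open, from the compounds shown here alone, is whether replacing the methyl ester of compound 1 with a carboxylic acid or an amide would move the number in this assay.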